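Swapping the amide ring: hydroxypyrrolidine to morpholine

A few compounds are considered here, and "the series" means these few. Any claim that something is new, unique, unknown or untested is made for them only; others in the source may bear on it.

Compound 1 `CN1CCN(C(=O)CC2CC[C@H](C(=O)N3CCN(c4ccccc4)CC3)[C@@H](C(=O)NO)C2)CC1` gives 30 nM in an assay on isolated protein for inhibition of disintegrin and metalloproteinase domain-containing protein 10 (Homo sapiens); a lower number here means a stronger inhibitor, a higher number a weaker inhibitor.
Compound 2 `O=C(NO)[C@H]1CC(CC(=O)N2CC[C@@H](O)C2)CC[C@@H]1C(=O)N1CCN(c2ccccc2)CC1` gives 111 nM in this assay.

For the measured compounds named here, of the two measured compounds, compound 2 stands with the higher number in this assay; its only neighbour is compound 1, reached by a 3.7-fold higher number from compound 1 to compound 2 (0.57 log units; beyond the scatter). Compound 3 `O=C(NO)[C@H]1CC(CC(=O)N2CCOCC2)CC[C@@H]1C(=O)N1CCN(c2ccccc2)CC1` is not yet measured. It differs from compound 2 by morpholin-4-yl in place of 3-hydroxypyrrolidin-1-yl on a carbonyl carbon. Going by the values given here, the one measured step that bears on this position, a 3.7-fold higher number from compound 1 to compound 2 (0.57 log units; beyond the scatter), shows that exchanging the ring on this carbonyl carbon moves the number modestly. Morpholin-4-yl, like 4-methylpiperazin-1-yl, is a six-membered ring with two hetero atoms, so compound 3 is expected to sit between compound 1 and compound 2, with a modest drop in the number, a 2.0-fold lower number from compound 2 to compound 3 (0.30 log units; within the scatter). Compound 3 is therefore estimated at 55 nM in this assay, within 20 nM to 150 nM.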

Compound 3, half-maximal inhibitory concentration: 83 nM
For compound 3 the middle estimate is 1.5-fold (0.18 log units) below the measured one; measured number inside the range.
By their numbers in this assay, from the lowest: compound 1; then compounds 3 and 2 (each within the scatter of the next).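

In this assay the exchange of 3-hydroxypyrrolidin-1-yl for morpholin-4-yl gives a 1.3-fold lower number from compound 2 to compound 3 (0.13 log units; within the scatter) and so does not separate the two groups on this carbonyl carbon, even though they differ in ring size, hydrogen-bond donor count and defined stereocentre. The exchange of 4-methylpiperazin-1-yl for morpholin-4-yl gives a 2.8-fold higher number from compound 1 to compound 3 (0.44 log units; beyond the scatter) and shows that a six-membered ring with two hetero atoms is not enough to match compound 1; among these three compounds, only 4-methylpiperazin-1-yl stands apart. Nothing available explains this difference.

The compounds shown leave open whether the methyl group or the second ring nitrogen of 4-methylpiperazin-1-yl sets compound 1 apart. Also open, on these data alone, is where piperazin-1-yl without the methyl group, or an open-chain dimethylamino group, would fall on this carbonyl carbon.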